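The source may hold more compounds than are shown below. What is called first, only, known or untested is meant among the compounds shown, and "the series" means these compounds.

Notes on the series

Three compounds share one core and carry a chlorine-bearing bicyclic unit joined through a cis-alkene to a trifluoromethyl-substituted phenyl ring. Compound 1 `FC(F)(F)c1ccc(/C=C\c2cc3ccccc3nc2Cl)cc1` gives 5360 nM in a functional assay on MDA-MB-231 cells (Homo sapiens) for antiproliferative activity, read by sulforhodamine B assay, with a stated time of 72 h; a lower number here means a stronger inhibitor, a higher number a weaker inhibitor. Compound 2 `COc1ccc2nc(Cl)c(/C=C\c3ccc(C(F)(F)F)cc3)cc2c1` adds a methoxy group to the bicyclic unit and gives 22800 nM in this assay. Compound 3 `COc1ccc2nc(Cl)c(/C=C\c3cc(C(F)(F)F)cc(C(F)(F)F)c3)cc2c1` keeps that methoxy and carries a second trifluoromethyl group on the phenyl ring; in this assay compound 3 gives 4470 nM, close to compound 1 and lower than compound 2. The difference between the cores of compound 2 and compound 3 is not broken down here.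

Among the compounds with values here, the one change that is measured in matched form is hydrogen in place of methoxy on an aromatic carbon. It gives a 4.3-fold lower number from compound 2 to compound 1 (0.63 log units; beyond the scatter).

Compound 4 `FC(F)(F)c1cc(/C=C\c2cc3ccccc3nc2Cl)cc(C(F)(F)F)c1` is not yet measured. It differs from compound 3 by hydrogen in place of methoxy on an aromatic carbon, the same kind of change, at a place described in the same words. Within the data shown here, the expectation for compound 4 rests on the step from compound 2 to compound 1, a 4.3-fold lower number from compound 2 to compound 1 (0.63 log units; beyond the scatter), since that is the only measured instance of this change; compound 3 already sits near compound 1, so a step of the full size is not assumed, and a 2.2-fold lower number from compound 3 to compound 4 (0.35 log units; beyond the scatter) is the step expected instead. On that basis compound 4 is estimated at 2000 nM in this assay, with a plausible range from 700 nM to 6000 nM.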

Compound 4, half-maximal inhibitory concentration: 10100 nM
The estimate for compound 4 lay 5.1-fold (0.70 log units) below the measured number; the measured number lies above the stated range.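

Hydrogen in place of methoxy on an aromatic carbon now gives a 2.3-fold higher number from compound 3 to compound 4 (0.35 log units; beyond the scatter) in this assay. The effect of this change therefore does not transfer between the two cores of this series, one carrying a single trifluoromethyl group and the other two, and even its direction is not preserved: the same change on two cores in this assay, a 4.3-fold lower number (0.63 log units; beyond the scatter) from compound 2 to compound 1 and a 2.3-fold higher number (0.35 log units; beyond the scatter) from compound 3 to compound 4, 9.6-fold (0.98 log units) apart, beyond the scatter of two such steps. This rests on one matched pair per core in a single assay, so it shows that a step measured on one core is a poor guide to the other, but it does not show which feature of the cores accounts for the reversal, or that the second trifluoromethyl group is responsible.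

The compounds shown leave open whether the reversal is tied to trifluoromethyl groups specifically or would also appear with another group on the phenyl ring, such as a nitrile or an amine. They also leave open how the two cores would respond to something other than methoxy or hydrogen at that aromatic carbon, such as a hydroxyl group or a longer ether chain.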